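This account rests on a few compounds, and the source may have more. Where it says the series, first, only, none or still open, it means among the compounds named here.

Series notes. The shared core carries an amide whose chain ends in an amine, and the three measured compounds differ only at that amine. Compound 1 `Cc1ccccc1-c1cc(C(=O)NCCCN(C)C)c2cn[nH]c2n1` in an assay on isolated protein for inhibition of N-lysine methyltransferase SMYD2 (Homo sapiens) (on this read-out higher numbers stand for weaker inhibition and lower numbers for stronger inhibition), gives > 61000 nM, which is a limit of the assay and not a number. Compound 2 `CNCCCNC(=O)c1cc(-c2ccccc2C)nc2[nH]ncc12` in this assay likewise gives only a limit, > 83000 nM. Among the measured compounds shown here, compound 3 `Cc1ccccc1-c1cc(C(=O)NCCCN2CCCCC2)c2cn[nH]c2n1` in this assay gives 13500 nM, the only number among the three values shown, so compound 3 is the reference point of the set. The step from compound 1 to compound 2 a step that the two limits leave unreadable from compound 1 to compound 2 stays unreadable because the limit of > 61000 nM in this assay, at which 1 of the 3 values shown sits, and the limit of > 83000 nM in this assay, at which 1 of the 3 values shown sits, cap both values. Putting a piperidin-1-yl in place of the smaller amines gives an at least 4.5-fold lower number from compound 1 to compound 3 (0.65 log units; beyond the scatter) and an at least 6.1-fold lower number from compound 2 to compound 3 (0.78 log units; beyond the scatter), each beyond the scatter and each toward stronger inhibition.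

Compound 4 `Cc1ccccc1-c1cc(C(=O)NCCCN2CCC(N3CCCCC3)CC2)c2cn[nH]c2n1` differs from compound 3 by piperidin-1-yl in place of hydrogen on a saturated ring carbon. The two readable steps favour the ring amine over the smaller amines, but neither tests growth of that ring itself, so the expectation rests on a loose analogy. A step of a 2.7-fold lower number from compound 3 to compound 4 (0.43 log units; beyond the scatter) in this assay is estimated, toward a lower number. Compound 4 is therefore expected to give 5000 nM in this assay, with a range from 1500 nM to 30000 nM.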

Compound 4, half-maximal inhibitory concentration: 19600 nM
Estimate against measurement, compound 4: 3.9-fold (0.59 log units) below, and the stated range covers the measured number.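

Putting piperidin-1-yl in place of hydrogen on the saturated ring carbon, three ring bonds from the ring nitrogen, gives a 1.5-fold higher number from compound 3 to compound 4 (0.16 log units; within the scatter) in this assay. The earlier compounds shown here differ only in the amine at the end of the chain, and their readable steps lie beyond the scatter, whereas this change adds a second six-membered non-aromatic ring at this carbon and leaves compound 3 and compound 4 unseparated by this read-out, so the position accepts this large group without a readable gain or loss. No measurement shown here gives a reason for this step.

Open, from the compounds shown here alone, is whether a small group on the same ring carbon, such as hydroxyl, or a charged one, such as a carboxylic acid, would separate from compound 3, which gives 13500 nM in this assay. Also open, going by these compounds, is whether a longer chain between the amide nitrogen and the piperidine ring would change the number beyond the scatter, with or without piperidin-1-yl on the ring carbon.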